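Series notes: removing one chloro from compound 1

The source may hold more compounds than are shown below. What is called first, only, known or untested is meant among the compounds shown, and "the series" means these compounds.

Three compounds of the shared core have been run in a functional assay on HUVEC cells (Homo sapiens) for inhibition, read by MTT assay, with a stated time of 24 h, tested at 100 uM; on this read-out higher numbers stand for more inhibition of growth at the one concentration tested and lower numbers for less inhibition of growth. Compound 2 `COc1cc2ccc(=O)oc2cc1OCC1CO1` gives 95.5%, compound 3 `COc1cc2ccc(=O)oc2cc1OCCNC(C)C` gives 0.1%, and compound 1 `COc1cc2ccc(=O)oc2cc1OCC(=O)c1ccc(Cl)c(Cl)c1` gives 42.8%, the second highest of the three numbers and beyond the scatter from each of the other two. Going by the values given here, the only step known within the set, a number 95.4 percentage points lower from compound 2 to compound 3 (beyond the scatter), concerns a different part of the molecule and says nothing about a chloro group on a six-membered aromatic ring of carbon only. Compound 4 `COc1cc2ccc(=O)oc2cc1OCC(=O)c1ccc(Cl)cc1` differs from compound 1 by hydrogen in place of chloro on an aromatic carbon. Among the compounds with values here, no measured step bears on this change, so the expectation rests on compound 1 alone: a step not beyond the scatter, in no firm direction, is expected, a number 4.8 percentage points lower from compound 1 to compound 4 (within the scatter). Compound 4 is therefore estimated at 38%, within 15% to 62%.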

Compound 4, percent growth inhibition at one concentration: 83.8%
Compound 4: the middle estimate sits 45.8 percentage points below what was measured, and the stated range ends below it.
By their numbers in this assay, from the lowest: compound 3; then compound 1; then compound 4; then compound 2.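

In this assay hydrogen in place of chloro on an aromatic carbon, ortho to a chloro group and meta to a large group, gives a number 41 percentage points higher from compound 1 to compound 4 (beyond the scatter) and shows that this position is not neutral for growth inhibition. The change of 3,4-dichlorophenyl to 4-chlorophenyl removes a single heavy atom, yet the step is large. Nothing at hand accounts for the size of this step. Still open, as far as these compounds go, is what the remaining chloro contributes, as the phenyl analogue without chloro is absent here. Also open, from the compounds shown here alone, is how fluoro, methoxy or an amine would behave on this aromatic carbon.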